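The source may report more compounds than this note shows. Statements on the series, on what has been measured and on what is new or still open speak of the compounds shown alone.

Among the compounds with values here, compound 2 `CN(C)C(=O)c1cccnc1NCCCN1CCN(c2ccccc2-c2ncco2)CC1` shows the lowest number so far in a functional assay for antagonist activity at Alpha-1A adrenergic receptor (Oryctolagus cuniculus) (on this read-out higher numbers stand for weaker binding and lower numbers for tighter binding), where compound 2 gives 0.316 nM. Within the data shown here, the only other measured compound, compound 1 `CN(C)C(=O)c1cccnc1NCCCN1CCN(c2ccccc2-c2ccccc2)CC1`, gives 1.26 nM in this assay, and the step of a 4.0-fold lower number from compound 1 to compound 2 (0.60 log units; beyond the scatter) shows how much the change mattered. Compound 3 `CN(C)C(=O)c1cccnc1NCCCN1CCN(c2ccccc2Cc2ccccc2)CC1` carries a different change: benzyl in place of 1,3-oxazol-2-yl on an aromatic carbon. Benzyl resembles the phenyl of compound 1 more than the 1,3-oxazol-2-yl of compound 2, so the step is expected to run back toward compound 1, giving a 4.7-fold higher number from compound 2 to compound 3 (0.68 log units; beyond the scatter). Compound 3 is therefore expected to give about 1.5 nM, with a range from 0.4 nM to 5 nM.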

Compound 3, dissociation constant: 6.31 nM
Estimate against measurement, compound 3: 4.2-fold (0.62 log units) below; measured number above the stated range.
By their numbers in this assay, from the lowest: compound 2; then compound 1; then compound 3.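

In this assay benzyl gives a 20-fold higher number from compound 2 to compound 3 (1.30 log units; beyond the scatter) and also a 5.0-fold higher number from compound 1 to compound 3 (0.70 log units; beyond the scatter) so, on this aromatic carbon, benzyl does not behave like phenyl even though both bring a six-membered aromatic ring of carbon only. Of the three groups seen here, 1,3-oxazol-2-yl gives the lowest number and benzyl the highest. Nothing available explains this order.

The compounds shown leave open whether pyridin-2-yl, a six-membered ring containing nitrogen, would match 1,3-oxazol-2-yl. They also leave open how a smaller group such as methoxy would compare.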